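The compounds below may be only part of what the source reports. "The series", "measured", "known", "first", "only" and "open" are said of these compounds alone.

Measured so far in an assay on HEK293 cells for agonist activity at transient receptor potential cation channel subfamily M member 8 (Homo sapiens), read by fluorescence and calcium flux, with a stated time of 15 min; on this read-out higher numbers stand for an effect only at larger amounts of compound and lower numbers for an effect already at smaller amounts:
compound 1, `Cc1ccc(OCC(=O)N(Cc2cccs2)C2CCCCC2)cc1`: 40000 nM
compound 2, `Cc1ccc(OCC(=O)N(Cc2cccs2)c2ccccc2)cc1`: 23 nM

For the measured compounds named here, compound 2 holds the lowest of the two numbers in this assay; its only neighbour is compound 1, and the single measured step, a 1700-fold lower number from compound 1 to compound 2 (3.24 log units; beyond the scatter), is the one in which phenyl replaces cyclohexyl on an amide-type nitrogen. Compound 3, `Cc1ccc(OCC(=O)N(Cc2cccs2)C2CC2)cc1`, has not yet been measured in this assay. It differs from compound 2 by cyclopropyl in place of phenyl on an amide-type nitrogen. The step of a 1700-fold lower number from compound 1 to compound 2 (3.24 log units; beyond the scatter) bears on this change, since it too exchanges one carbon ring for another at the same nitrogen, and there the non-aromatic ring carried the far higher number. Going by the values given here, no measured compound carries cyclopropyl, so the size of the coming step is uncertain. A step of an 87-fold higher number from compound 2 to compound 3 (1.94 log units; beyond the scatter) toward higher numbers is therefore expected. Compound 3 is estimated at 2000 nM, with a range from 200 nM to 40000 nM.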

Compound 3, half-maximal effective concentration: 8 nM
Beside the measured number, compound 3's estimate is 250-fold (2.40 log units) above it; measured number below the stated range.
By their numbers in this assay, from the lowest: compound 3; then compound 2; then compound 1.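

In this assay, the earlier step could be read as favouring an aromatic ring on the amide-type nitrogen, but the non-aromatic cyclopropyl removes that reading, with a 2.9-fold lower number from compound 2 to compound 3 (0.46 log units; beyond the scatter) going past phenyl rather than falling behind it. The two non-aromatic rings also lie far apart, with a 5000-fold lower number from compound 1 to compound 3 (3.70 log units; beyond the scatter), so the high number of compound 1 belongs to cyclohexyl in particular and not to non-aromatic rings in general. Nothing given here explains why these rings differ so widely.

The compounds shown leave open how the number responds to other groups on this nitrogen, such as cyclobutyl, isopropyl or a longer chain, and whether a ring is needed there at all. They also leave open whether cyclopropyl keeps its place ahead of phenyl when the rest of the shared core changes.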